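Formyl for ethyl on the aryl ring of compound 3

The source may report more compounds than this note shows. Statements on the series, on what has been measured and on what is new or still open speak of the compounds shown alone.

Of the compounds shown here, three sharing one core have been tested in a functional assay on SNB-75 cells (Homo sapiens) for inhibition, read by sulforhodamine B assay, with a stated time of 48 h, tested at 10 uM; on this read-out lower numbers stand for less inhibition and higher numbers for more inhibition at the one concentration tested (going by the name of the read-out). Compound 1 `c1ccc(-c2cn3ccnc3c(-c3ccc4ncn(C5CCCCC5)c4c3)n2)cc1` gives 44.4%, compound 2 `COc1ccccc1-c1cn2ccnc2c(-c2ccc3ncn(C4CCCCC4)c3c2)n1` gives 35%, and compound 3 `CCc1ccc(-c2cn3ccnc3c(-c3ccc4ncn(Cc5ccccc5)c4c3)n2)cc1` gives 29.3%. Among the measured compounds shown here, the only single-point step among them is a number 9.4 percentage points lower from compound 1 to compound 2 (within the scatter). Compound 3 stands lowest of the three numbers: its value lies within the scatter of compound 2 but beyond the scatter below compound 1.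

Compound 4 `O=Cc1ccc(-c2cn3ccnc3c(-c3ccc4ncn(Cc5ccccc5)c4c3)n2)cc1` has not yet been measured in this assay. It differs from compound 3 in one place: formyl in place of ethyl on an aromatic carbon. For the measured compounds named here, only one measured step bears on a substituent exchanged on that six-membered aromatic ring of carbon only, the change from compound 1 to compound 2, and that step stayed within the scatter. Going by the values given here, no measured pair shows what a formyl group does on this ring, so the direction of the step cannot be read from the data. He therefore expects a step of a number 0.7 percentage points higher from compound 3 to compound 4 (within the scatter), within the scatter, in this assay. His estimate for compound 4 is 30%, with a range from 12% to 48%.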

Compound 4, a percentage reported as inhibition, at one concentration (the size of the read-out at that concentration, not a potency): 21.4%
Compound 4: the middle estimate sits 8.6 percentage points above what was measured, and the stated range covers the measured number.
By their numbers in this assay, from the lowest: compounds 4, 3, 2 and 1 (each within the scatter of the next, the first and the last beyond it).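

In this assay, among the compounds shown here, the exchange of ethyl for formyl gives a number 7.9 percentage points lower from compound 3 to compound 4 (within the scatter), the first measured exchange of one group for another on an aromatic carbon para to a large group. Formyl has the same count of heavy atoms as ethyl but brings an oxygen, a double bond outside the aromatic rings and a hydrogen-bond acceptor, and with these changes the step still does not pass beyond the scatter, so this single pair shows no measurable effect of the exchange at this place. Nothing measured explains the size or the direction of this step, and no outside evidence bears on it.

The compounds shown leave open what an amine, a carboxylic acid or a longer chain on this same carbon would do in this assay, and whether any group there would give a step beyond the scatter. They also leave open whether formyl in place of ethyl would give a similar step with cyclohexyl in place of the benzyl group that compound 3 and compound 4 share.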